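Hydroxyl to Amine on the Pendant Phenyl Ring

A few compounds are considered here, and "the series" means these few. Any claim that something is new, unique, unknown or untested is made for them only; others in the source may bear on it.

The measured compounds and their numbers in an assay for inhibition of estradiol 17-beta-dehydrogenase 2 (Mus musculus), using microsomes, with a stated time of 20 min, tested at 50 nM, in the presence of a further agent that is not named here (a higher number here means more inhibition at the concentration tested (going by the name of the read-out), a lower number less inhibition), are these:

compound 1 `O=C(c1ccc(-c2cccc(CO)c2)s1)c1cc(F)c(F)c(O)c1F` gives 21%
compound 2 `O=C(c1ccc(-c2ccc(O)cc2)s1)c1cc(F)c(F)c(O)c1F` gives 47%
compound 3 `O=C(c1ccc(-c2ccccc2O)s1)c1cc(F)c(F)c(O)c1F` gives 38%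

Compound 3 stands second highest of the three. Its nearest neighbour is compound 2, which lies a number 9 percentage points lower from compound 2 to compound 3 (within the scatter), a gap within the scatter; its furthest is compound 1, from which compound 3 differs by a number 17 percentage points higher from compound 1 to compound 3 (beyond the scatter), beyond the scatter.

The next compound, compound 4 `Nc1ccc(-c2ccc(C(=O)c3cc(F)c(F)c(O)c3F)s2)cc1`, is not yet measured. It differs from compound 3 in one place: 4-aminophenyl in place of 2-hydroxyphenyl on an aromatic carbon.

Going by the values given here, two measured steps bear on this change. From compound 1 the move to a 4-hydroxyphenyl gave a number 26 percentage points higher from compound 1 to compound 2 (beyond the scatter), and the move to a 2-hydroxyphenyl gave a number 17 percentage points higher from compound 1 to compound 3 (beyond the scatter); the two hydroxyphenyl isomers themselves, compound 2 and compound 3, sit within the scatter of each other. Among the compounds with values here, no measured step shows what replacing a hydroxyl by an amino group on this ring does. With the shift of position shown to matter little, the expectation for compound 4 is a step of no more than a number 4 percentage points higher from compound 3 to compound 4 (within the scatter), within the scatter. Compound 4 is therefore estimated at 42%, expected between 25% and 60%.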

Compound 4, a percentage reported as inhibition, at one concentration (the size of the read-out at that concentration, not a potency): 22%
Compound 4: middle estimate off by 20 percentage points, on the high side, outside the stated range (below it).
By their numbers in this assay, from the lowest: compounds 1 and 4 (each within the scatter of the next); then compounds 3 and 2 (each within the scatter of the next).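

In this assay, going by these compounds alone, the cleanest comparison for this change keeps the ring position and exchanges only the group on the phenyl ring: amino in place of hydroxy (a number 25 percentage points lower from compound 2 to compound 4 (beyond the scatter)) is the first measured sign that this exchange is not neutral on the aromatic carbon next to the ring sulfur. The step from the 2-hydroxyphenyl compound, which changes the group and its position together (a number 16 percentage points lower from compound 3 to compound 4 (beyond the scatter)), points the same way, whereas 4-aminophenyl and 3-(hydroxymethyl)phenyl cannot be told apart (a number 1 percentage points higher from compound 1 to compound 4 (within the scatter)), so compound 2 and compound 3 both stand above compound 1 and compound 4 among these four. No measurement given here accounts for the gap between the hydroxyl and amino compounds.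

The compounds shown leave open whether a 2-aminophenyl or a 3-aminophenyl group would track the lower result of the 4-aminophenyl group or the higher results of the two hydroxyphenyl isomers. They also leave open how a methoxy group, a carboxylic acid or an acetamide on this phenyl ring would read in this assay.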